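Swapping an Alkene for a Phenyl on the Triazole Arm

This account rests on a few compounds, and the source may have more. Where it says the series, first, only, none or still open, it means among the compounds named here.

Compound 3 `C=C(C)c1cn(-c2cccc(C(=O)/C=C/c3ccc(O)c(OC)c3)c2)nn1` gives 9790 nM in a functional assay on RAW264.7 cells (Mus musculus) for inhibition, with a stated time of 4 days; a higher number here means a weaker inhibitor, a lower number a stronger inhibitor. Of the three measured numbers it stands second highest: compound 1 `COc1cc(/C=C/C(=O)c2cccc(N=[N+]=[N-])c2)ccc1O` gives 7110 nM and compound 2 `COc1cc(/C=C/C(=O)c2cccc(-n3cc(C(C)(C)O)nn3)c2)ccc1O` gives 19800 nM. The step of a 1.4-fold higher number from compound 1 to compound 3 (0.14 log units; within the scatter) lies within the scatter, whereas a 2.0-fold lower number from compound 2 to compound 3 (0.31 log units; beyond the scatter) lies beyond it, though only modestly. Compound 4 `COc1cc(/C=C/C(=O)c2cccc(-n3cc(-c4ccccc4)nn3)c2)ccc1O` differs from compound 3 by phenyl in place of 1-methylethenyl on an aromatic carbon. Within the data shown here, the only measured step at that same aromatic carbon of the five-membered aromatic ring with 3 nitrogen is a 2.0-fold lower number from compound 2 to compound 3 (0.31 log units; beyond the scatter), and it was modest, so a step in this assay of similar size or smaller is expected, most likely downward or within the scatter: the expected step is a 1.4-fold lower number from compound 3 to compound 4 (0.15 log units; within the scatter). Compound 4 is therefore estimated at about 7000 nM, with a range from 3000 nM to 16000 nM.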

Compound 4, half-maximal inhibitory concentration: 16800 nM
Compound 4: the middle estimate sits 2.4-fold (0.38 log units) below what was measured, outside the stated range (above it).
By their numbers in this assay, from the lowest: compounds 1, 3, 4 and 2 (each within the scatter of the next, the first and the last beyond it).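

In this assay, a ring on this aromatic carbon of the five-membered aromatic ring with 3 nitrogen gives a step within the scatter in both available comparisons (a 1.7-fold higher number from compound 3 to compound 4 (0.23 log units; within the scatter)) and (a 1.2-fold lower number from compound 2 to compound 4 (0.07 log units; within the scatter)). Phenyl therefore cannot be told apart here from either 1-methylethenyl or 1-hydroxy-1-methylethyl, even though those two groups differ from each other beyond the scatter. No supporting evidence is available to explain this result.

From the compounds shown here alone, whether an amine or a carboxylic acid on this carbon would give a clearly lower number remains open.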